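Swapping Chlorine for Fluorine in a Non-Toxic Series

The source may report more compounds than this note shows. Statements on the series, on what has been measured and on what is new or still open speak of the compounds shown alone.

Three compounds share one core and differ only in the group carried on a saturated chain carbon bound to an aromatic nitrogen. Compound 1 is `O=c1ccoc2cc(OCc3cn(Cc4ccc([N+](=O)[O-])cc4)nn3)ccc12`, compound 2 is `Cc1ccccc1Cn1cc(COc2ccc3c(=O)ccoc3c2)nn1` and compound 3 is `O=c1ccoc2cc(OCc3cn(Cc4ccc(Cl)cc4)nn3)ccc12`. Each was tested in an ADME assay on L02 cells (Homo sapiens) for cytotoxicity, read by MTT assay, with a stated time of 48 h; on this read-out lower numbers stand for stronger inhibition and higher numbers for weaker inhibition. Compound 1 gives > 300000 nM, which is a limit of the assay rather than a number. Compound 2 likewise reaches only the limit > 300000 nM. Compound 3 also stops at the limit > 300000 nM. Compound 3 therefore stands exactly where its neighbours stand: the limit of > 300000 nM in this assay, at which 3 of the 3 values shown sit. Because all three values are limits, the steps between them cannot be read: a step that the two limits leave unreadable from compound 1 to compound 2, a step that the two limits leave unreadable from compound 1 to compound 3 and a step that the two limits leave unreadable from compound 2 to compound 3.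

Compound 4, `O=c1ccoc2cc(OCc3cn(Cc4ccccc4F)nn3)ccc12`, has not yet been measured. It differs from compound 3 by 2-fluorophenyl in place of 4-chlorophenyl on a saturated chain carbon bound to an aromatic nitrogen. For the measured compounds named here, the three measured steps bear on this change only by showing that varying this same group has never moved the read-out off the limit, so no step of readable size exists and no direction can be expected beyond the scatter. Compound 4 is therefore expected to give 300000 nM, between 150000 nM and 600000 nM, most probably reported again as a limit. The implied step a number no higher from compound 3 to compound 4 (the limit leaves the size open) is expected to be nothing beyond the scatter.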

Compound 4, half-maximal inhibitory concentration: > 300000 nM
Compound 4: only a limit was reported; the forecaster's own chance of this, stated with the estimate: 85%; the middle value sits exactly at the limit.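

No step linking compound 4 to compound 1, compound 2 or compound 3 can be read, because all four compounds report only a limit and not a number: the limit of > 300000 nM in this assay, at which 4 of the 4 values shown sit.

The compounds shown leave open how far each one lies beyond that limit, and whether any group at this place would give a readable value.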